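Fluoro on the benzoyl group of sigma receptor ligands

The compounds below may be only part of what the source reports. "The series", "measured", "known", "first", "only" and "open" are said of these compounds alone.

Compound 1 `O=C(c1ccccc1)N1CCC(NCC[S+]([O-])C(c2ccc(F)cc2)c2ccc(F)cc2)CC1` gives 585 nM in an assay on membranes from Cortex for displacement of a labelled ligand from Sigma non-opioid intracellular receptor 1 (Cavia porcellus), read by scintillation counting, with a stated time of 120 min; on this read-out lower numbers stand for stronger inhibition and higher numbers for weaker inhibition. Compound 2 `O=C(c1ccc(F)cc1)N1CCC(NCC[S+]([O-])C(c2ccc(F)cc2)c2ccc(F)cc2)CC1` gives 1440 nM in this assay. Between them stands one change, (fluoro in place of hydrogen on an aromatic carbon), which produced a 2.5-fold higher number from compound 1 to compound 2 (0.39 log units; beyond the scatter). Compound 3 `O=C(c1ccccc1F)N1CCC(NCCSC(c2ccc(F)cc2)c2ccc(F)cc2)CC1` gives 3.57 nM in this assay, the lowest of the three numbers; the difference between its core and the core of compound 1 is not broken down here. Compound 4 `O=C(c1ccc(F)cc1F)N1CCC(NCCSC(c2ccc(F)cc2)c2ccc(F)cc2)CC1` is not yet measured and differs from compound 3 by fluoro in place of hydrogen on an aromatic carbon. This is the same kind of change as that between compound 1 and compound 2, though here the place is meta to a fluoro group as well as para to a large group. That earlier step was modest, and compound 4 is therefore expected to show a similar step, a 2.2-fold higher number from compound 3 to compound 4 (0.35 log units; beyond the scatter). Compound 4 is estimated at 8 nM, expected to lie between 3 nM and 25 nM.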

Compound 4, inhibition constant: 20.6 nM
Estimate against measurement, compound 4: 2.6-fold (0.41 log units) below; low and high end bracket the measured number.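

In this assay the added fluoro gave a 5.8-fold higher number from compound 3 to compound 4 (0.76 log units; beyond the scatter), the same direction as on the core of compound 1. Set beside the earlier step, the change carried across the two cores with no size difference that can be told apart: the same change on two cores in this assay, a 2.5-fold higher number (0.39 log units; beyond the scatter) from compound 1 to compound 2 and a 5.8-fold higher number (0.76 log units; beyond the scatter) from compound 3 to compound 4, 2.3-fold (0.37 log units) apart, within the scatter of two such steps This rests on only two pairs, which differ both in their core and in the benzoyl group that receives the fluoro, so it shows neither a general rule nor which of these differences matters.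

The compounds shown leave open whether a chloro or a methoxy group in the same place would give a similar step. Among the compounds shown here, they also leave open whether the step would hold with a longer chain in place of the one in these compounds.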